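Aryl hydrazone series: rat whole-organism dosing, limits only

A few compounds are considered here, and "the series" means these few. Any claim that something is new, unique, unknown or untested is made for them only; others in the source may bear on it.

Compound 1 `Cc1cccc(NN=C2CCC(C)n3c2ncc(C(=O)O)c3=O)c1C` in a functional assay on the whole organism with Rattus norvegicus as the target (a higher number here means that more compound is needed for the effect, a lower number that less compound is needed), gives only the limit > 100 umol/kg. Compound 2 `Cc1ccc(NN=C2CCC(C)n3c2ncc(C(=O)O)c3=O)cc1C` in this assay gives only the limit > 100 umol/kg. Compound 3 `CC1CCC(=NNc2ccc(Br)cc2Cl)c2ncc(C(=O)O)c(=O)n21` in this assay gives only the limit > 100 umol/kg.

Compound 3 thus stands where every measured value in this series stands, at the limit of > 100 umol/kg in this assay, at which 3 of the 3 values shown sit. No measured value is a number; each is a limit of the assay. The three steps among the measured compounds, a step that the two limits leave unreadable from compound 1 to compound 2, a step that the two limits leave unreadable from compound 1 to compound 3 and a step that the two limits leave unreadable from compound 2 to compound 3, are therefore unreadable in size and direction: exchanging one aryl group on the amine nitrogen for another has not moved any compound off the limit.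

Compound 4 `Cc1cc(NN=C2CCC(C)n3c2ncc(C(=O)O)c3=O)ccc1Br` differs from compound 3 by 4-bromo-3-methylphenyl in place of 4-bromo-2-chlorophenyl on an amine nitrogen. The three unreadable steps are the only ones that bear on this change, and they give no size to work from. The expectation for compound 4 is therefore that it too is reported at or near the limit, with the step that the limit leaves unreadable from compound 3 to compound 4 expected from compound 3. Compound 4 is estimated at 150 umol/kg, in a range from 60 umol/kg to 400 umol/kg, with a high chance that the assay again reports only a limit.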

Compound 4, dose for 50% inhibition: > 100 umol/kg
Compound 4 gave a limit, no number; the forecaster's own chance of this, stated with the estimate: 70%; the middle value lies beyond the limit too.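

In this assay compound 4 also gives only a limit, and its steps from compound 1, compound 2 and compound 3 cannot be read: the limit of > 100 umol/kg in this assay, at which 4 of the 4 values shown sit.

The compounds shown leave open whether any aryl group on the amine nitrogen moves a compound off this limit, and how far these four compounds differ.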